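The source may hold more compounds than are shown below. What is called first, only, known or untested is meant among the compounds shown, and "the series" means these compounds.

Compound 1 `CC1(C)[C@H]2CC[C@]1(C)N(Cc1cn(-c3ccc(C#N)cc3)nn1)C(=O)C2`: 140 nM
Compound 2 `COc1ccccc1-n1cc(CN2C(=O)C[C@@H]3CC[C@@]2(C)C3(C)C)nn1`: 350 nM
Compound 3 `CC1(C)[C@H]2CC[C@]1(C)N(Cc1cn(-c3ccc(O)cc3)nn1)C(=O)C2`: not yet measured

For the measured compounds named here, in a functional assay on A549 cells (Homo sapiens) for inhibition, read by MTT assay, with a stated time of 24 h (a lower number here means a stronger inhibitor, a higher number a weaker inhibitor), compound 2 gives 350 nM, the higher of the two numbers so far, which makes it the weaker inhibitor of the pair. Compound 3 keeps the shared core and changes one group: 4-hydroxyphenyl in place of 2-methoxyphenyl on an aromatic nitrogen. Going by the values given here, only one measured step bears on this. It changes the group at the same place and is modest: a 2.5-fold higher number from compound 1 to compound 2 (0.40 log units; beyond the scatter). That single step suggests that a 4-substituted phenyl may do better here than 2-methoxyphenyl, although a hydroxyl is not a nitrile and the data hold no phenol to compare. A modest move towards a lower number is therefore expected in this assay, an expected change of a 1.6-fold lower number from compound 2 to compound 3 (0.20 log units; within the scatter). For compound 3 the estimated value is 220 nM, with an expected range of 80 nM to 600 nM.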

Compound 3, half-maximal inhibitory concentration: 140 nM
The estimate for compound 3 lay 1.6-fold (0.20 log units) above the measured number; the range from low to high includes it.
By their numbers in this assay, from the lowest: compounds 1 and 3 (each within the scatter of the next); then compound 2.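

In this assay the move to 4-hydroxyphenyl in place of 2-methoxyphenyl on the aromatic nitrogen reads (a 2.5-fold lower number from compound 2 to compound 3 (0.40 log units; beyond the scatter)), so compound 2 stands apart from both other compounds. Hydroxy in place of cyano on the aromatic carbon reads (no change at the digits printed from compound 1 to compound 3 (within the scatter)), which shows that at this place on the phenyl ring, a nitrile and a hydroxyl give numbers that cannot be told apart in this assay. No measurement here explains why these groups read alike or why 2-methoxyphenyl stands apart.

2-methoxyphenyl differs from the other two groups both in the group itself and in where it sits, so these compounds cannot say which of the two matters. 4-methoxyphenyl would separate them, while 4-aminophenyl or a carboxylic acid at the same place would test how far this tolerance extends.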